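Urea substituent variation on the shared core

The compounds below may be only part of what the source reports. "The series", "measured", "known", "first", "only" and "open" are said of these compounds alone.

Measured compounds:
compound 1 `COCCNC(=O)Nc1cc2c(Nc3ccc(F)c(Cl)c3)ncnc2cc1O[C@H]1CCOC1` — 387 nM
compound 2 `O=C(Nc1cc2c(Nc3ccc(F)c(Cl)c3)ncnc2cc1O[C@H]1CCOC1)N1CC(O)C1` — 1930 nM
compound 3 `CN1CCN(C(=O)Nc2cc3c(Nc4ccc(F)c(Cl)c4)ncnc3cc2O[C@H]2CCOC2)CC1` — 675 nM

In a functional assay on A-431 cells (Homo sapiens) for antiproliferative activity, read by sulforhodamine B assay, with a stated time of 72 h (a higher number here means a weaker inhibitor, a lower number a stronger inhibitor), compound 3 stands second highest of the three numbers. The step of a 1.7-fold higher number from compound 1 to compound 3 (0.24 log units; within the scatter) lies within the scatter, whereas a 2.9-fold lower number from compound 2 to compound 3 (0.46 log units; beyond the scatter) lies beyond it. Compound 4 `O=C(Nc1cc2c(Nc3ccc(F)c(Cl)c3)ncnc2cc1O[C@H]1CCOC1)N1CCC(F)CC1` differs from compound 3 by 4-fluoropiperidin-1-yl in place of 4-methylpiperazin-1-yl on a carbonyl carbon. Among the compounds with values here, no measured step swaps one cyclic amine for another on the carbonyl carbon, so nothing bears on it directly; the nearest guide is the modest step of a 2.9-fold lower number from compound 2 to compound 3 (0.46 log units; beyond the scatter), which shows that changing the cyclic amine can move the number beyond the scatter, without fixing a direction. A step of at most modest size is therefore expected in this assay, giving a 1.2-fold higher number from compound 3 to compound 4 (0.07 log units; within the scatter). For compound 4 the expected value is 800 nM, with a range of 300 nM to 2500 nM.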

Compound 4, half-maximal inhibitory concentration: 3040 nM
Compound 4: the middle estimate sits 3.8-fold (0.58 log units) below what was measured; the whole stated range lies below it.
By their numbers in this assay, from the lowest: compounds 1 and 3 (each within the scatter of the next); then compounds 2 and 4 (each within the scatter of the next).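

In this assay, 4-fluoropiperidin-1-yl in place of 4-methylpiperazin-1-yl on the carbonyl carbon gives a step beyond the scatter (a 4.5-fold higher number from compound 3 to compound 4 (0.65 log units; beyond the scatter)), so two six-membered rings of equal heavy-atom count are not interchangeable at this position. The new group stands within the scatter of 3-hydroxyazetidin-1-yl (a 1.6-fold higher number from compound 2 to compound 4 (0.20 log units; within the scatter)) but well apart from (2-methoxyethyl)amino (a 7.9-fold higher number from compound 1 to compound 4 (0.90 log units; beyond the scatter)). No available evidence accounts for these differences.

From the compounds shown here alone, whether the gap follows the ring nitrogen or the fluorine stays open; piperidin-1-yl without fluorine, or morpholin-4-yl, on the same carbonyl carbon would help separate them.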